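The compounds below may be only part of what the source reports. "The series", "measured", "known", "first", "only" and "open" are said of these compounds alone.

Measured so far:
Compound 1, `COc1cc(-c2nn(-c3cccc(NC(=O)Nc4ccc(Cl)c(Cl)c4)c3)cc2-c2ccncc2)ccc1Cl`: > 50000 nM
Compound 2, `O=C(Nc1cccc(-n2cc(-c3ccncc3)c(-c3ccc(Cl)c(O)c3)n2)c1)Nc1ccc(Cl)c(Cl)c1`: > 32500 nM

Both of these are read in a functional assay on SW-620 cells (Homo sapiens) for inhibition, read by sulforhodamine B assay, with a stated time of 48 h; a higher number here means a weaker inhibitor of growth, a lower number a stronger inhibitor of growth. Compound 2 gives > 32500 nM, which is a limit of this assay rather than a number. Compound 1 likewise gives > 50000 nM, again only a limit. For the measured compounds named here, the one measured step, a step that the two limits leave unreadable from compound 1 to compound 2, therefore has no readable size, so compound 2 stands at a limit with nothing to rank it against beyond the limit of > 32500 nM in this assay, at which 1 of the 2 values shown sits, and (the limit of > 50000 nM in this assay, at which 1 of the 2 values shown sits).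

Compound 3, `O=C(Nc1cccc(-n2cc(-c3ccncc3)c(-c3ccc(Cl)c(O)c3)n2)c1)Nc1ccc(Cl)c(C(F)(F)F)c1`, differs from compound 2 by trifluoromethyl in place of chloro on an aromatic carbon, a trifluoromethyl in place of chloro on an aromatic carbon, ortho to a chloro group and meta to a large group. Going by the values given here, no measured step bears on this change, and the only neighbours are limits, so for this step no size beyond the scatter is expected in this assay; the estimated step is a step that the limit leaves unreadable from compound 2 to compound 3. Compound 3 is therefore estimated at 50000 nM, within 15000 nM to 100000 nM, most likely again reported only as a limit.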

Compound 3, concentration for total growth inhibition: 4160 nM
Compound 3: middle estimate off by 12-fold (1.08 log units), on the high side, outside the stated range (below it).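

For the compounds shown here, replacing chloro with trifluoromethyl at this position gives, in this assay, an at least 7.8-fold lower number from compound 2 to compound 3 (0.89 log units; beyond the scatter), and this is the first step that can be read, since the earlier step cannot. A change at a single place on the aromatic ring, ortho to a chloro group, is thus enough to take this scaffold from a limit of the assay to a measured number. The full size of the step stays unknown, because compound 2 is reported only as a limit: the limit of > 32500 nM in this assay, at which 1 of the 3 values shown sits.

The compounds shown leave open whether trifluoromethyl is special here or whether a bromo, methyl or nitrile group at the same position would serve as well. They also leave open whether the same replacement would work with the methoxy group of compound 1 in place of the hydroxy group.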